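The compounds below may be only part of what the source reports. "The series", "measured", "known", "first", "only" and "open" are said of these compounds alone.

Measured so far in a functional assay on KB cells (Homo sapiens) for cytotoxicity; a lower number here means a stronger inhibitor, a higher number a weaker inhibitor:
compound 1 `COc1ccc(S(=O)(=O)N2CCc3cccc(NS(=O)(=O)c4ccccc4)c32)cc1`: 650 nM
compound 2 `COc1ccc(S(=O)(=O)N2CCc3cccc(NC(=O)c4ccco4)c32)cc1`: 9.6 nM

Compound 2, at 9.6 nM, holds the lower of the two numbers, and its gap to compound 1 lies beyond the scatter. Next is compound 3 `COc1ccc(S(=O)(=O)N2CCc3cccc(NC(=O)N(C)c4ccccc4)c32)cc1`, which keeps the carbonyl of compound 2. The change is methyl(phenyl)amino in place of furan-2-yl on a carbonyl carbon, in words methyl(phenyl)amino in place of furan-2-yl on a carbonyl carbon.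

Among the measured compounds shown here, only one measured step bears on this: a 68-fold lower number from compound 1 to compound 2 (1.83 log units; beyond the scatter), a large step. It replaced phenylsulfonyl with (furan-2-yl)carbonyl, so it shows that this assay can respond strongly to a change on this nitrogen. For the measured compounds named here, it does not isolate the group on the carbonyl carbon, and no measured compound carries methyl(phenyl)carbamoyl. A move to a higher number is therefore expected, smaller than that large step but probably beyond the scatter, with wide uncertainty. The estimated step is a 6.3-fold higher number from compound 2 to compound 3 (0.80 log units; beyond the scatter). Compound 3 is expected at 60 nM, with an estimated range of 12 nM to 300 nM.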

Compound 3, half-maximal inhibitory concentration: > 10000 nM
Compound 3 ended at the assay's limit; the forecaster's own chance of this, stated with the estimate: 3%; at least 160-fold (2.22 log units) between middle value and limit.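

Compound 3 stands at a limit of this assay, not at a measured number: the limit of > 10000 nM in this assay, at which 1 of the 3 values shown sits.

With the carbonyl kept, the group on the carbonyl carbon decides the outcome on its own, as shown by an at least 1000-fold higher number from compound 2 to compound 3 (3.01 log units; beyond the scatter). The low number of compound 2 therefore cannot be credited to the carbonyl alone, a point the step from compound 1 to compound 2 could not settle because it changed the sulfonyl and the group beyond it together. A carbonyl on this nitrogen also does not guarantee an advantage over phenylsulfonyl: the series gives an at least 15-fold higher number from compound 1 to compound 3 (1.18 log units; beyond the scatter), so methyl(phenyl)carbamoyl goes against the direction seen with (furan-2-yl)carbonyl.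

On these data alone, the true size of both steps remains open, since each rests on a limit and has no upper end. Also open, as far as these compounds go, is which feature of methyl(phenyl)amino goes with the loss: a plain phenylamino group, a phenyl directly on the carbonyl carbon, or a thiophen-2-yl in place of furan-2-yl would help separate the nitrogen, the methyl and the ring, and would show whether furan-2-yl itself is needed.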